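From piperidine to imidazole on the side chain

A few compounds are considered here, and "the series" means these few. Any claim that something is new, unique, unknown or untested is made for them only; others in the source may bear on it.

In a functional assay on ECa-109 cells (Homo sapiens) for antiproliferative activity, read by MTT assay, with a stated time of 48 h (on this read-out higher numbers stand for weaker inhibition and lower numbers for stronger inhibition), compound 1 (`Cn1cc(C2=C(c3nn(CCCn4cncn4)c4ncccc34)C(=O)NC2=O)c2ccccc21`) gives > 100000 nM, which is a limit of the assay. Compound 2 (`Cn1cc(C2=C(c3nn(CCCn4cncn4)c4ncccc34)C(=O)N(c3ccccc3)C2=O)c2ccccc21`) gives > 100000 nM, again only a limit. Among the compounds with values here, compound 3 (`Cn1cc(C2=C(c3nn(CCCN4CCCCC4)c4ncccc34)C(=O)N(c3ccccc3)C2=O)c2ccccc21`) stands at 12300 nM, the only actual number among the three. Compound 4 (`Cn1cc(C2=C(c3nn(CCn4ccnc4)c4ncccc34)C(=O)N(c3ccccc3)C2=O)c2ccccc21`) brings (1H-imidazol-1-yl in place of (piperidin-1-yl)methyl on a saturated chain carbon, two bonds along the chain from an aromatic nitrogen), turning 3-(piperidin-1-yl)propyl into 2-(1H-imidazol-1-yl)ethyl. Within the data shown here, the one step that bears on this is an at least 8.1-fold lower number from compound 2 to compound 3 (0.91 log units; beyond the scatter), which put piperidin-1-yl in place of 1H-1,2,4-triazol-1-yl. Compound 4 again gives up the piperidine ring for an aromatic one, so a move towards weaker inhibition is expected. The expected change is a 3.7-fold higher number from compound 3 to compound 4 (0.56 log units; beyond the scatter). For compound 4 the estimated value is 45000 nM, with an expected range of 13000 nM to 100000 nM.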

Compound 4, half-maximal inhibitory concentration: 8770 nM
The estimate for compound 4 lay 5.1-fold (0.71 log units) above the measured number; measured number outside the range, below it.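

Swapping the piperidine ring for an aromatic ring did not separate the two compounds in this assay, with a 1.4-fold lower number from compound 3 to compound 4 (0.15 log units; within the scatter), so an aromatic ring on this chain does not by itself bring the weak result of the triazole compounds. The two aromatic side chains differ instead, with an at least 11-fold lower number from compound 2 to compound 4 (1.05 log units; beyond the scatter). That step rests on a limit of the assay: the limit of > 100000 nM in this assay, at which 2 of the 4 values shown sit.

Compound 4 alters ring and chain length together, and a 3-(1H-imidazol-1-yl)propyl chain would separate the two. On these data alone, how a morpholine ring or a primary amine would fare on this chain stays open.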